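Benzyl to pentyl swap on the sulfur substituent

The source may hold more compounds than are shown below. What is called first, only, known or untested is meant among the compounds shown, and "the series" means these compounds.

Measured so far:
compound 1 `Nc1ncnc2c1nc(O)n2Cc1ccc(Cl)cc1`, 10 uM
compound 2 `Nc1nc(SCc2ccccc2)nc2c1nc(O)n2Cc1ccccc1`, 0.1 uM
compound 3 `Nc1ncnc2c1nc(S)n2Cc1ccccc1`, 10 uM

In a functional assay (spleen, spleen) for activation, with Mus musculus as the target (on this read-out lower numbers stand for an effect already at smaller amounts and higher numbers for an effect only at larger amounts of compound), compound 2 gives the lowest number of the three; compound 1 and compound 3 each sit higher by a margin beyond the scatter, and those two show the same value. Compound 4 `CCCCCSc1nc(N)c2nc(O)n(Cc3ccccc3)c2n1` follows from compound 2 by one change: butyl in place of phenyl on a saturated chain carbon bound to a sulfur. Within the data shown here, no step between measured compounds that differ in one place is available, so the size of this move has no precedent in the set; the benzylsulfanyl group is the only feature separating compound 2 from the other two. A small shift toward higher numbers, or none beyond the scatter, is expected. For compound 4 the estimated value is 0.2 uM (range 0.03 uM to 1 uM). The expected step is a 2.0-fold higher number from compound 2 to compound 4 (0.30 log units; within the scatter).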

Compound 4, minimum effective concentration: 10 uM
Beside the measured number, compound 4's estimate is 50-fold (1.70 log units) below it, outside the stated range (above it).
By their numbers in this assay, from the lowest: compound 2; then compounds 1, 3 and 4 (each within the scatter of the next).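

In this assay, butyl in place of phenyl on a saturated chain carbon bound to a sulfur gives a 100-fold higher number from compound 2 to compound 4 (2.00 log units; beyond the scatter). This position is therefore sensitive to the change, and a saturated chain does not stand in for the phenyl: within this pair, the low number goes with benzylsulfanyl and not with pentylsulfanyl.

From the compounds shown here alone, whether the low number requires a ring at this place, or phenyl specifically, stays open; cyclohexyl, pyridyl or chlorophenyl would help separate those readings. No data shown bear on the cause of the step.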